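A Side-Chain Swap on the Shared Core

The source may report more compounds than this note shows. Statements on the series, on what has been measured and on what is new or still open speak of the compounds shown alone.

Measured in an ADME assay on J774 cells (Mus musculus) for cytotoxicity; on this read-out lower numbers stand for an effect already at smaller amounts and higher numbers for an effect only at larger amounts of compound:
compound 1 `COc1cc2[nH]c(C)c(C(C)C)c(=O)c2cc1Cl`: 21700 nM
compound 2 `CCCCC#Cc1c(C)[nH]c2cc(OC)c(Cl)cc2c1=O`: 15000 nM

For the measured compounds named here, compound 2 stands level with compound 1, the only other compound measured. Compound 3 `C=C(CCCCC)c1c(C)[nH]c2cc(OC)c(Cl)cc2c1=O` is not yet measured, and it departs from compound 2 on the same aromatic carbon: a group of 7 heavy atoms (7 carbon; no ring) in place of a group of 6 heavy atoms (6 carbon; no ring), on an aromatic carbon. Going by the values given here, one measured step bears on this carbon: hex-1-yn-1-yl in place of isopropyl shows a 1.4-fold lower number from compound 1 to compound 2 (0.16 log units; within the scatter). On that evidence, no change beyond the scatter is expected in this assay. The expected step is no change at the digits printed from compound 2 to compound 3 (within the scatter). Compound 3 is estimated at 15000 nM, with an expected range of 7000 nM to 30000 nM.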

Compound 3, half-maximal effective concentration in the J774 assay: 18900 nM
The estimate for compound 3 lay 1.3-fold (0.10 log units) below the measured number, and the stated range covers the measured number.
By their numbers in the J774 assay, from the lowest: compounds 2, 3 and 1 (each within the scatter of the next).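

In the J774 assay the new side chain leaves the picture unchanged, with a 1.3-fold higher number from compound 2 to compound 3 (0.10 log units; within the scatter) and a 1.1-fold lower number from compound 1 to compound 3 (0.06 log units; within the scatter), so all three carbon-only groups on this aromatic carbon read alike. In a physicochemical assay for lipophilicity, at pH 7.4 (a lower number here means a more polar compound, a higher number a more lipophilic compound), compound 2 gives 2.45 and compound 3 gives 3.58. In the physicochemical assay the same swap does register, which shows that this cytotoxicity read-out can stay level across a large shift in lipophilicity: the measured distribution coefficient of compound 2, 2.45, and of compound 3, 3.58, a number 1.13 log units higher (beyond the scatter). The compounds shown leave open whether an amine or a carboxylic acid on this carbon would move the number in the J774 assay beyond the scatter.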